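Amino Addition Repeated on a Rearranged Core

The compounds below may be only part of what the source reports. "The series", "measured", "known", "first", "only" and "open" are said of these compounds alone.

Of the compounds shown here, three have been measured in a functional assay on MDA-MB-231 cells (Homo sapiens) for cytotoxicity, read by sulforhodamine B assay, with a stated time of 48 h (on this read-out lower numbers stand for stronger inhibition of growth and higher numbers for weaker inhibition of growth), and one more awaits a result. Compound 1 `ClCc1ccc(Cn2cnc3c(Cl)ncnc32)cc1` gives 1770 nM in this assay. Compound 2 `Nc1nc(Cl)c2ncn(Cc3ccc(CCl)cc3)c2n1` carries one change relative to compound 1, namely (amino in place of hydrogen on an aromatic carbon), and in this assay compound 2 gives 13200 nM. The step that this change produced is a 7.5-fold higher number from compound 1 to compound 2 (0.87 log units; beyond the scatter), a weakening of growth inhibition that lies beyond the usual scatter.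

Compound 3 `ClCc1ccccc1Cn1cnc2c(Cl)ncnc21` is built from the same atoms as compound 1, joined differently; the difference between the two cores is not broken down here. In this assay compound 3 gives 3020 nM, a number close to that of compound 1 and within the scatter of it.

Compound 4 `Nc1nc(Cl)c2ncn(Cc3ccccc3CCl)c2n1` is the not yet measured member of the set. It differs from compound 3 by amino in place of hydrogen on an aromatic carbon, which is the same change as that from compound 1 to compound 2, made at a place described in the same words. Within the data shown here, since compound 3 and compound 1 sit within the scatter of each other in this assay, and the only example of this change is the step of a 7.5-fold higher number from compound 1 to compound 2 (0.87 log units; beyond the scatter), the expectation is a step of comparable size, a 6.6-fold higher number from compound 3 to compound 4 (0.82 log units; beyond the scatter), from compound 3 to compound 4. On that basis compound 4 is estimated to give about 20000 nM in this assay, with a plausible range from 8000 nM to 50000 nM.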

Compound 4, concentration for 50% growth inhibition: 2950 nM
For compound 4 the middle estimate is 6.8-fold (0.83 log units) above the measured one; the whole stated range lies above it.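

On the core of compound 3, amino in place of hydrogen on an aromatic carbon produces a 1.0-fold lower number from compound 3 to compound 4 (0.01 log units; within the scatter) in this assay and so leaves the number unmoved within the usual scatter. Set beside the earlier step, the same change does not have the same size on the two cores: the same change on two cores in this assay, a 7.5-fold higher number (0.87 log units; beyond the scatter) from compound 1 to compound 2 and a 1.0-fold lower number (0.01 log units; within the scatter) from compound 3 to compound 4, 7.6-fold (0.88 log units) apart, beyond the scatter of two such steps.
In this series, then, a step read on one core cannot be relied on to hold for the other, even when the change is described in the same words; these two pairs do not show what in the cores makes the steps part, and two pairs set no rule for any further core.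

The compounds shown leave open whether other groups put in the same place, such as a methylamino group, a hydroxyl group or a methoxy group, would also give steps of different size on the two cores. They also leave open whether the two cores would part in the same way if a thiol group or a longer chain stood in place of the chloro group.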